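Lengthening a Chain on a Shared Core

The compounds below may be only part of what the source reports. "The series", "measured", "known", "first", "only" and "open" are said of these compounds alone.

Three compounds share one core and differ at a single chain carbon. In a functional assay on HL-60 cells (Homo sapiens) for cytotoxicity, read by WST assay, with a stated time of 48 h (on this read-out higher numbers stand for weaker inhibition and lower numbers for stronger inhibition), compound 1 `COC[C@H](C(C)C)C(c1ccc(O)c(OC)c1)c1ccc(O)c(OC)c1` gives 72000 nM, compound 2 `COc1cc(C(c2ccc(O)c(OC)c2)[C@H](CC(C)C)C(C)C)ccc1O` gives 9600 nM, and compound 3 `CC[C@H](C(C)C)C(c1ccc(O)c(OC)c1)c1ccc(O)c(OC)c1` gives 16000 nM, the second highest of the three numbers. The steps of a 7.5-fold lower number from compound 1 to compound 2 (0.88 log units; beyond the scatter) and a 4.5-fold lower number from compound 1 to compound 3 (0.65 log units; beyond the scatter) were modest and beyond the scatter, whereas a 1.7-fold higher number from compound 2 to compound 3 (0.22 log units; within the scatter) stayed within it. Compound 4 `CCCCCCCC[C@H](C(C)C)C(c1ccc(O)c(OC)c1)c1ccc(O)c(OC)c1` differs from compound 3 by hexyl in place of hydrogen on a saturated chain carbon, four bonds along the chain from two aromatic carbons. Within the data shown here, no measured step swaps hydrogen for a chain of this length, so the closest guide is the small gap between compound 2 and compound 3. Compound 4 is therefore expected to move only slightly, a 1.8-fold lower number from compound 3 to compound 4 (0.25 log units; within the scatter), with an estimated 9000 nM and a range from 3000 nM to 27000 nM.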

Compound 4, half-maximal inhibitory concentration: 3700 nM
The estimate for compound 4 lay 2.4-fold (0.39 log units) above the measured number; low and high end bracket the measured number.
By their numbers in this assay, from the lowest: compound 4; then compounds 2 and 3 (each within the scatter of the next); then compound 1.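

Hexyl in place of hydrogen on this saturated chain carbon gives a 4.3-fold lower number from compound 3 to compound 4 (0.64 log units; beyond the scatter) in this assay, so a far longer chain at this position moves the number beyond the scatter, which the swap of isopropyl for methyl did not do. Heptyl in place of isopropyl also gives a step beyond the scatter, a 2.6-fold lower number from compound 2 to compound 4 (0.41 log units; beyond the scatter), while heptyl in place of methoxy gives a 19-fold lower number from compound 1 to compound 4 (1.29 log units; beyond the scatter), the only large step in the set. No supporting measurement accounts for these shifts.

As far as these compounds go, whether a longer chain such as decyl would lower the number further remains open. So does whether an amine or a carboxylic acid at the end of the chain would preserve the lower number.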